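A few compounds are considered here, and "the series" means these few. Any claim that something is new, unique, unknown or untested is made for them only; others in the source may bear on it.

Measured compounds:
- compound 1 `CCCn1c(=O)[nH]c2nc(-c3ccc(S(=O)(=O)N4CCN(c5cccc(Br)c5)CC4)cc3)[nH]c2c1=O`: 0.234 nM
- compound 2 `CCCn1c(=O)[nH]c2nc(-c3ccc(S(=O)(=O)N4CCN(c5ccccc5Br)CC4)cc3)[nH]c2c1=O`: 0.137 nM
- compound 3 `CCCn1c(=O)[nH]c2nc(-c3ccc(S(=O)(=O)N4CCN(c5ccc(Br)cc5)CC4)cc3)[nH]c2c1=O`: 0.0835 nM

In an assay on CHO cells for displacement of a labelled ligand from adenosine receptor A2b (Homo sapiens), read by scintillation counting, with a stated time of 75 min, in the presence of a further agent that is not named here (on this read-out lower numbers stand for stronger inhibition and higher numbers for weaker inhibition), compound 1 stands at the highest of the three numbers. The step to compound 2 is small, a 1.7-fold lower number from compound 1 to compound 2 (0.23 log units; within the scatter), whereas the step to compound 3 is larger, a 2.8-fold lower number from compound 1 to compound 3 (0.45 log units; beyond the scatter); between the other two, a 1.6-fold lower number from compound 2 to compound 3 (0.22 log units; within the scatter).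

Compound 4 `CCCn1c(=O)[nH]c2nc(-c3ccc(S(=O)(=O)N4CCN(c5ccccc5)CC4)cc3)[nH]c2c1=O` differs from compound 1 by hydrogen in place of bromo on an aromatic carbon. The measured steps all move the bromo from one position on the ring to another; none removes it, so they bear on this change only loosely. Even the largest of them is modest, and no step beyond the scatter is expected here, in either direction. For compound 4 a value of 0.3 nM is estimated, with a range of 0.1 nM to 0.9 nM. That estimate means an expected step of a 1.3-fold higher number from compound 1 to compound 4 (0.11 log units; within the scatter).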

Compound 4, inhibition constant: 0.643 nM
For compound 4 the middle estimate is 2.1-fold (0.33 log units) below the measured one; low and high end bracket the measured number.
By their numbers in this assay, from the lowest: compounds 3, 2 and 1 (each within the scatter of the next, the first and the last beyond it); then compound 4.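

In this assay, within the data shown here, the bromo is taken away for the first time, and the change to phenyl raises the number from each bromophenyl compound, beyond the scatter every time (a 2.7-fold higher number from compound 1 to compound 4 (0.44 log units; beyond the scatter); a 4.7-fold higher number from compound 2 to compound 4 (0.67 log units; beyond the scatter); a 7.7-fold higher number from compound 3 to compound 4 (0.89 log units; beyond the scatter)). So among these compounds, having a bromo on this ring matters, wherever it sits, and compound 4 gives a higher number than all three. No measurement shown here explains this.

Still open, on these data alone, is whether chloro, methoxy or an amine on this ring would match bromo, and whether a second bromo would lower the number further.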